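Working notes: hydroxy to methoxy on the aromatic ring

The compounds below may be only part of what the source reports. "The series", "measured", "known", "first", "only" and "open" are said of these compounds alone.

Series values in a functional assay on BHK-21 cells (Mesocricetus auratus) for antiproliferative activity, read by sulforhodamine B assay, with a stated time of 48 h, tested at 1 uM (on this read-out lower numbers stand for less inhibition of growth and higher numbers for more inhibition of growth at the one concentration tested), so far:
- compound 1 `Fc1ccc(OCc2nn3c(-c4ccncc4)nnc3s2)cc1` gives 45.4%
- compound 2 `Oc1ccc(OCc2nn3c(-c4ccncc4)nnc3s2)cc1` gives 53.7%
- compound 3 `COc1ccc(OCc2nn3c(-c4ccncc4)nnc3s2)cc1` has no measurement yet

Among the measured compounds shown here, only two numbers exist, and compound 2 at 53.7% cannot be separated from compound 1 at 45.4% in this assay on this evidence. Compound 3 differs from compound 2 by methyl in place of hydrogen on an oxygen on an aromatic ring and so turns hydroxy into methoxy, with the shared core untouched. For the measured compounds named here, one measured step bears on this, hydroxy in place of fluoro on an aromatic carbon, which reads a number 8.3 percentage points higher from compound 1 to compound 2 (within the scatter) and gives no sign that this group moves the number. Going by the values given here, no measured compound carries methoxy, so the support is indirect and thin. Expected here is a number 3.7 percentage points lower from compound 2 to compound 3 (within the scatter) and thus no step beyond the scatter in either direction. Compound 3 is estimated at 50% in this assay (expected range 35% to 65%).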

Compound 3, percent growth inhibition at one concentration: 68.8%
Compound 3: the middle estimate sits 18.8 percentage points below what was measured, and the stated range ends below it.
By their numbers in this assay, from the lowest: compounds 1 and 2 (each within the scatter of the next); then compound 3.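

In this assay, methyl in place of hydrogen on the oxygen gives a step beyond the scatter, a number 15.1 percentage points higher from compound 2 to compound 3 (beyond the scatter), whereas hydroxy in place of fluoro on the same aromatic carbon did not separate compound 1 from compound 2. Methoxy in place of fluoro also clears the scatter, a number 23.4 percentage points higher from compound 1 to compound 3 (beyond the scatter), so compound 3 stands highest of the three and methoxy is the only one of these three groups that sets itself apart. This position on the aromatic ring can therefore move the growth-inhibition number, and a change as small as one added methyl is enough to do so, but nothing available explains why.

Going by these compounds, whether the gain stays with methoxy or carries over to a longer chain on the same oxygen, such as ethoxy or propoxy, remains open, as does the effect of an amine or a carboxylic acid at this position. The three compounds also share the rest of the structure and were read at a single concentration, so they leave open whether the step holds at other concentrations or with other parts of the core changed.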